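A few compounds are considered here, and "the series" means these few. Any claim that something is new, unique, unknown or untested is made for them only; others in the source may bear on it.

Measured so far:
- compound 1, `CN1CCN(CCCS(=O)(=O)c2ccc3nc(NC(=O)NC(=O)c4cc(C5CC5)ccc4Cl)sc3c2)CC1`: 1400 nM in an ADME assay on the whole organism (strain Han-Wistar) for pharmacokinetics, with Rattus norvegicus as the target, read by LC-MS, at a dose of 2 mg/kg by the oral route; on this read-out higher numbers stand for higher exposure at the dose given and lower numbers for lower exposure
- compound 2, `CCN(CC)CCCS(=O)(=O)c1ccc2nc(NC(=O)NC(=O)c3cc(-n4cccn4)ccc3Cl)sc2c1`: 1600 nM

Both numbers come from this assay, and compound 1 and compound 2 sit within the scatter of each other, so the two readings show no order between them; compound 1 simply holds one of the two values known for this series.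

Compound 3, `CN1CCN(CCCS(=O)(=O)c2ccc3nc(NC(=O)NC(=O)c4cc5c(ccn5C)cc4Cl)sc3c2)CC1`, is not yet measured. It differs from compound 1 in one place: 5-chloro-1-methyl-1H-indol-6-yl in place of 2-chloro-5-cyclopropylphenyl on a carbonyl carbon. The shared core with its sulfonyl-linked basic chain is unchanged, and compound 2 shows that a second variant of the same core with a different aryl group gives a value in the same region as compound 1.

Going by the values given here, no step between measured compounds is known for this kind of change, so the expectation rests on the values of compound 1 and compound 2 alone. The step from compound 1 to compound 3 is expected to be small, a 1.2-fold lower number from compound 1 to compound 3 (0.07 log units; within the scatter), with no clear direction beyond the scatter. Compound 3 is therefore estimated at 1200 nM, within a range from 400 nM to 3600 nM.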

Compound 3, maximal plasma concentration: 300 nM
Estimate against measurement, compound 3: 4.0-fold (0.60 log units) above, and the stated range ends above it.
By their numbers in this assay, from the lowest: compound 3; then compounds 1 and 2 (each within the scatter of the next).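

At the aryl group on a carbonyl carbon whose other neighbour is an amide-type nitrogen, the read-out in this assay responds to the choice of group: 5-chloro-1-methyl-1H-indol-6-yl in place of 2-chloro-5-cyclopropylphenyl gives a 4.7-fold lower number from compound 1 to compound 3 (0.67 log units; beyond the scatter) with the rest of the molecule unchanged. Going by these compounds alone, compound 1 and compound 2 differ in more than one place, so this is the first step that isolates this position, and it shows that exchanging one aromatic group for another here need not leave the exposure in place. Nothing measured on these compounds speaks to what lies behind the step.

The change replaces the whole group in one move, so the part played by the loss of the cyclopropyl and the part played by the entry of the methylated indole stay unseparated; a 2-chlorophenyl carrying a nitrile or a trifluoromethyl group instead of the cyclopropyl, or the same indole without its methyl group, would address this. Also open, from the compounds shown here alone, is whether the step carries over to another amine on the chain, such as the diethylamino group of compound 2.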